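A Chlorophenyl Analogue Weighed Against Two Inactive Congeners

A few compounds are considered here, and "the series" means these few. Any claim that something is new, unique, unknown or untested is made for them only; others in the source may bear on it.

Of the compounds shown here, two with a shared core have been assayed. Compound 1 `Cc1ccc(CO/N=C2/C(c3c[nH]c4ccc(Br)cc34)=Nc3ccc(Br)cc32)cc1` carries a methyl on an aromatic carbon and compound 2 `FC(F)(F)c1ccc(CO/N=C2/C(c3c[nH]c4ccc(Br)cc34)=Nc3ccc(Br)cc32)cc1` a trifluoromethyl in its place. In an ADME assay on HUVEC cells (Homo sapiens) for cytotoxicity, read by MTT assay, with a stated time of 2 days (on this read-out lower numbers stand for stronger inhibition and higher numbers for weaker inhibition), compound 1 reaches only the limit of the assay, > 100000 nM. In this assay compound 2 likewise returns only a limit, > 100000 nM. The step from methyl to trifluoromethyl, a step that the two limits leave unreadable from compound 1 to compound 2, therefore cannot be read, because both values sit at the limit of > 100000 nM in this assay, at which 2 of the 2 values shown sit, and compound 2 stands at that limit with no number of its own.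

Compound 3 `Clc1cccc(CO/N=C2/C(c3c[nH]c4ccc(Br)cc34)=Nc3ccc(Br)cc32)c1` is the next member. Its change from compound 2 is 3-chlorophenyl in place of 4-(trifluoromethyl)phenyl on a saturated chain carbon bound to an oxygen on an unsaturated carbon. Among the compounds with values here, the only measured step, a step that the two limits leave unreadable from compound 1 to compound 2, has no readable size, so nothing from the measured compounds bears on this change in this assay. Since both measured compounds sit at the limit of > 100000 nM in this assay, at which 2 of the 2 values shown sit, compound 3 is expected to stay at or near the limit, a step of a number no higher from compound 2 to compound 3 (the limit leaves the size open) estimated to be none beyond the scatter. Compound 3 is accordingly estimated at 100000 nM, within a range from 30000 nM to 300000 nM.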

Compound 3, half-maximal inhibitory concentration: > 100000 nM
Compound 3 was reported as a limit; the forecaster's own chance of this, stated with the estimate: 85%; the middle value sits exactly at the limit.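

In this assay compound 3 also returns only a limit, > 100000 nM. Its steps from compound 1 and compound 2 therefore cannot be read: the limit of > 100000 nM in this assay, at which 3 of the 3 values shown sit. The compounds shown leave open whether 4-methylphenyl, 4-(trifluoromethyl)phenyl and 3-chlorophenyl differ at all in this read-out, and at what concentration, if any, compound 1, compound 2 or compound 3 would reach half-maximal inhibition.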